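This account rests on a few compounds, and the source may have more. Where it says the series, first, only, none or still open, it means among the compounds named here.

Measured compounds, antiproliferative read-out in a functional assay on KB cells (Homo sapiens) for antiproliferative activity, read by colorimetric assay and MTT assay; on this read-out lower numbers stand for stronger inhibition and higher numbers for weaker inhibition:

Compound 1 `O=[N+]([O-])c1ccc(S(=O)(=O)Nc2cccc3c(Cl)c[nH]c23)cc1`: 14 ug/mL
Compound 2 `O=[N+]([O-])c1ccc(S(=O)(=O)Nc2ccc(Cl)c3cc[nH]c23)cc1`: 9.1 ug/mL
Compound 3 `N#Cc1ccc(S(=O)(=O)Nc2cccc3c(Cl)c[nH]c23)cc1`: 11 ug/mL

Compounds 1 and 3 share a core; compound 3 carries cyano in place of nitro on an aromatic carbon. The step in this assay is a 1.3-fold lower number from compound 1 to compound 3 (0.10 log units; within the scatter). Compound 2 is built on a different core; the difference between the two cores is not broken down here. Its value and those of compounds 1 and 3 lie within the usual scatter of one another, so no ordering among the three is supported.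

Compound 4 `N#Cc1ccc(S(=O)(=O)Nc2ccc(Cl)c3cc[nH]c23)cc1` has not been measured. It stands to compound 2 as compound 3 stands to compound 1, carrying (cyano in place of nitro on an aromatic carbon); the place of the change is the same in both pairs. Among the compounds with values here, on that basis, and because the only precedent is a 1.3-fold lower number from compound 1 to compound 3 (0.10 log units; within the scatter), the step is expected to be small, about a 1.2-fold lower number from compound 2 to compound 4 (0.08 log units; within the scatter). Compound 4 is therefore estimated at 7.5 ug/mL, between 3.5 ug/mL and 16 ug/mL.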

Compound 4, half-maximal inhibitory concentration: 15 ug/mL
Compound 4: the middle estimate sits 2.0-fold (0.30 log units) below what was measured; measured number inside the range.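

In this assay, cyano in place of nitro on an aromatic carbon gives a 1.6-fold higher number from compound 2 to compound 4 (0.22 log units; within the scatter), and the step on the other core does not differ from it beyond the scatter: the same change on two cores in this assay, a 1.3-fold lower number (0.10 log units; within the scatter) from compound 1 to compound 3 and a 1.6-fold higher number (0.22 log units; within the scatter) from compound 2 to compound 4, 2.1-fold (0.32 log units) apart, within the scatter of two such steps. On these two cores, then, nitro and cyano cannot be told apart in this read-out, and the opposite directions of the two steps carry no weight. This does not show that the change is without effect on other cores, nor that the two cores respond alike, as two small steps from single pairs cannot settle either point.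

Open, going by these compounds, is whether an amine or a carboxylic acid in the place of nitro would stand apart from these two groups. Also open, on these data alone, is what methyl or methoxy in the place of the chlorine on either core would give.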